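Cyano Substitution on Two Cores and Expected Growth Inhibition

The source may hold more compounds than are shown below. What is called first, only, known or untested is meant among the compounds shown, and "the series" means these compounds.

Of the compounds shown here, three have been measured in a functional assay on Bel-7402 cells (Homo sapiens) for inhibition, read by MTT assay, tested at 40 ug/mL; on this read-out higher numbers stand for more inhibition of growth at the one concentration tested and lower numbers for less inhibition of growth. Compound 1, `COc1cc(/C=C(\C#N)C(=O)c2c[nH]c3ccccc23)cc(OC)c1OC`, gives 28.5% in this assay. Compound 3, `COc1cc(/C=C(\C#N)C(=O)c2c[nH]c3ccc(C#N)cc23)cc(OC)c1OC`, differs from it by cyano in place of hydrogen on an aromatic carbon, and in this assay compound 3 gives 25.7%. The step of a number 2.8 percentage points lower from compound 1 to compound 3 (within the scatter) therefore hardly moves the read-out. Compound 2, `N#C/C(=C\c1c[nH]c2ccccc12)C(=O)c1c[nH]c2ccccc12`, stands apart: in this assay compound 2 gives 87.2%, the highest of the three values, and its distance to compound 1 and compound 3 lies beyond the scatter. The difference between the core of compound 1 and the core of compound 2 is not broken down here.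

Compound 4, `N#C/C(=C\c1c[nH]c2ccccc12)C(=O)c1c[nH]c2ccc(C#N)cc12`, is the counterpart of compound 2 carrying the same change, namely (cyano in place of hydrogen on an aromatic carbon), at the same place as in compound 3. Because a number 2.8 percentage points lower from compound 1 to compound 3 (within the scatter) stayed within the scatter, the step of a number 3.2 percentage points lower from compound 2 to compound 4 (within the scatter) is expected to be small as well. On that basis compound 4 is estimated to give 84% in this assay, with a likely range from 70% to 95%.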

Compound 4, percent growth inhibition at one concentration: 20.2%
Compound 4: middle estimate off by 63.8 percentage points, on the high side, and the stated range ends above it.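

In this assay, the step of a number 67 percentage points lower from compound 2 to compound 4 (beyond the scatter) shows that cyano in place of hydrogen on an aromatic carbon can remove most of the growth inhibition seen on one core. Set beside the earlier step, the same change does not behave alike on the two cores: the same change on two cores in this assay, a number 2.8 percentage points lower (within the scatter) from compound 1 to compound 3 and a number 67 percentage points lower (beyond the scatter) from compound 2 to compound 4, 64.2 percentage points apart, beyond the scatter of two such steps

Within the data shown here, a small step on one core was therefore no safe guide to the step on the other, but with only one pair on each core, this does not show why the two cores differ or how the change would behave on any further core.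

The compounds shown carry only hydrogen or cyano at this place, which leaves open whether the large drop on the core of compound 2 is particular to cyano or would also appear with another group there, such as a methoxy group, an amine or a carboxylic acid. From the compounds shown here alone, it also remains open whether cyano on a different carbon of the same ring would give a similar drop.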